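The source may report more compounds than this note shows. Statements on the series, on what has been measured and on what is new or still open speak of the compounds shown alone.

Two compounds of the series carry numbers in an assay on microsomes from intestine for inhibition of acyl-CoA:cholesterol acyltransferase (Oryctolagus cuniculus); a lower number here means a stronger inhibitor, a higher number a weaker inhibitor. Compound 1 `O=C(NC(=O)Oc1c(-c2ccccc2)cccc1-c1ccccc1)Oc1c(-c2ccccc2)cccc1-c1ccccc1` gives 230 nM. Compound 2 `CC(C)c1cccc(C(C)C)c1OC(=O)NC(=O)OC(c1ccccc1)c1ccccc1` gives 350 nM, the higher of the two numbers, though its nearest neighbour compound 1 lies within the scatter, so no order between them can be read. Compound 3 `CC(C)c1cccc(C(C)C)c1OC(=O)NC(=O)OCc1ccccc1` carries the change (hydrogen in place of phenyl on a saturated chain carbon bound to an aromatic carbon and an oxygen next to a carbonyl group). For the measured compounds named here, no measured pair shows such a step, so its size rests on the change alone. For compound 3 a moderate rise in the number, beyond the scatter, is expected, a 2.9-fold higher number from compound 2 to compound 3 (0.46 log units; beyond the scatter). Compound 3 is therefore estimated at 1000 nM, within 350 nM to 3000 nM.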

Compound 3, half-maximal inhibitory concentration: 77 nM
Beside the measured number, compound 3's estimate is 13-fold (1.11 log units) above it, and the stated range ends above it.
By their numbers in this assay, from the lowest: compound 3; then compounds 1 and 2 (each within the scatter of the next).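

At the saturated chain carbon bound to an aromatic carbon and an oxygen next to a carbonyl group, hydrogen in place of phenyl gives a 4.5-fold lower number from compound 2 to compound 3 (0.66 log units; beyond the scatter) in this assay. The phenyl lost from this carbon is therefore not required for inhibition among the compounds shown, and the smaller compound 3 is the stronger inhibitor of the pair. No measured information bears on the reason for this step.

From the compounds shown here alone, whether a methyl group or a longer chain at this carbon would retain the lower number stays open. So does the effect of an amine on the remaining phenyl.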